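Chloro to Iodo on Compound 1: An Expectation

This account rests on a few compounds, and the source may have more. Where it says the series, first, only, none or still open, it means among the compounds named here.

Of the compounds shown here, two of a shared core have been tested in a functional assay on the whole organism (uterus) with Rattus norvegicus as the target, tested at 10 uM; on this read-out lower numbers stand for a stronger effect and higher numbers for a weaker effect at the one concentration tested. Compound 1, `CC(C)Nc1nc(O)c2cc(Cl)ccc2n1`, gives 78.7% in this assay. Compound 2, `Oc1nc(NCC2CCCCC2)nc2ccc(Cl)cc12`, gives 86% in this assay. Of the two numbers, that of compound 1 is the lower one, but the gap to compound 2 lies within the scatter of repeated measurements, so the two compounds cannot be told apart on these data.

Compound 3, `CC(C)Nc1nc(O)c2cc(I)ccc2n1`, has not been measured. It differs from compound 1 in one place: iodo in place of chloro on an aromatic carbon. Among the measured compounds shown here, no pair of measured compounds shows the effect of such an exchange, so there is no measured step to lean on. Given that compound 1 gives 78.7% and that the halogen is the only thing changed, the step from compound 1 to compound 3 is expected to stay within the scatter, with no clear direction, as a number 0.7 percentage points lower from compound 1 to compound 3 (within the scatter) expresses. Compound 3 is therefore estimated at 78%, within a range from 60% to 95%.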

Compound 3, a percentage reported as activity, at one concentration (the size of the read-out at that concentration, not a potency): 77.6%
Estimate against measurement, compound 3: 0.4 percentage points above, within the range that was stated.
By their numbers in this assay, from the lowest: compounds 3, 1 and 2 (each within the scatter of the next).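

In this assay, among the compounds shown here, the exchange of chloro for iodo on this aromatic carbon gives a number 1.1 percentage points lower from compound 1 to compound 3 (within the scatter), the first step that reads this position directly. Compounds 1 and 2 both carry chloro here, so they could say nothing about a change at this carbon, whereas the new pair shows that iodo can take the place of chloro without a shift beyond the scatter. With the shared core and the rest of compound 1 held constant, these two halogens cannot be told apart at the one concentration tested, and no data at hand bear on the reason for this outcome.

The compounds shown leave open whether a group other than a halogen on this aromatic carbon, such as a nitrile, a methoxy group or an amine, would move the read-out beyond the scatter. For the compounds shown here, they also leave open whether iodo in place of chloro on compound 2 would give a step as small as the one seen on compound 1.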